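Replacing 3-methoxypyridin-2-yl with phenyl on compound 1

A few compounds are considered here, and "the series" means these few. Any claim that something is new, unique, unknown or untested is made for them only; others in the source may bear on it.

In an ADME assay on microsomes from liver (Homo sapiens) for metabolic stability, read by LC-MS, in the presence of a further agent that is not named here (a higher number here means faster removal of the compound, a lower number slower removal), the values so far are these
- compound 1 `COc1cccnc1-c1nc2ccc(-c3nc4c(C)ncc(C)n4n3)cc2[nH]1` gives 0.7 mL.min-1.g-1
- compound 2 `Cc1ncc(C)n2nc(-c3ccn4cc(-c5ccccc5)nc4n3)nc12` gives 1.8 mL.min-1.g-1

Compound 1 holds the lower of the two numbers, and the gap up to compound 2 lies beyond the usual scatter. Compound 3 `Cc1ncc(C)n2nc(-c3ccc4nc(-c5ccccc5)[nH]c4c3)nc12` has phenyl in place of 3-methoxypyridin-2-yl on an aromatic carbon. For the measured compounds named here, no measured pair isolates this change. Going by the values given here, the only guide is compound 2, which also carries phenyl (1.8 mL.min-1.g-1), so a modest upward move is expected. The estimated step is a rise (a 2.1-fold higher number from compound 1 to compound 3 (0.33 log units; beyond the scatter)). In this assay the expected value for compound 3 is 1.5 mL.min-1.g-1 with an estimated range from 0.7 mL.min-1.g-1 to 3.5 mL.min-1.g-1 once measured.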

Compound 3, intrinsic clearance in microsomes: 34.4 mL.min-1.g-1
The estimate for compound 3 lay 23-fold (1.36 log units) below the measured number; the measured number lies above the stated range.
By their numbers in this assay, from the lowest: compound 1; then compound 2; then compound 3.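

Swapping 3-methoxypyridin-2-yl for phenyl gives a 49-fold higher number from compound 1 to compound 3 (1.69 log units; beyond the scatter) in this assay and shows that the group on this aromatic carbon, between two ring nitrogen atoms, can strongly change the result while the core stays the same. The swap removes the ring nitrogen and the methoxy group together, so this single step cannot separate their contributions. Nothing measured here explains the rise.

As far as these compounds go, it remains open whether a plain pyridin-2-yl or a methoxyphenyl would give a number closer to that of compound 1 or compound 3. How an amine at this position would behave is also unknown.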